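Amine swap on the core: compound 3 to compound 4

A few compounds are considered here, and "the series" means these few. Any claim that something is new, unique, unknown or untested is made for them only; others in the source may bear on it.

Within the data shown here, in an ADME assay on MCF-10A cells (Homo sapiens) for cytotoxicity, read by sulforhodamine B assay, with a stated time of 48 h (on this read-out higher numbers stand for weaker inhibition of growth and lower numbers for stronger inhibition of growth), compound 3 `O=C1C(=O)N(CN2CCCCC2)c2cccc(Cl)c21` gives 70700 nM, the second highest of the three numbers so far; compound 1 `O=C1C(=O)N(CN2CCCCC2)c2cccc(Br)c21` gives 66900 nM and compound 2 `CCN(CC)CN1C(=O)C(=O)c2c(Br)cccc21` gives 113000 nM. The step of a 1.1-fold higher number from compound 1 to compound 3 (0.02 log units; within the scatter) lies within the scatter. Compound 4 `CCN(CC)CN1C(=O)C(=O)c2c(Cl)cccc21` differs from compound 3 by diethylamino in place of piperidin-1-yl on a saturated chain carbon bound to an amide-type nitrogen in a ring. The same exchange has been seen once, as a 1.7-fold higher number from compound 1 to compound 2 (0.23 log units; within the scatter), which stayed within the scatter. A step of similar size and direction in this assay is therefore expected for compound 4, with the real possibility that it falls within the scatter. The estimate for compound 4 is 105000 nM, with a range from 50000 nM to 220000 nM. The expected step is a 1.5-fold higher number from compound 3 to compound 4 (0.17 log units; within the scatter).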

Compound 4, concentration for 50% growth inhibition: 35000 nM
Compound 4: the middle estimate sits 3.0-fold (0.48 log units) above what was measured; the measured number lies below the stated range.
By their numbers in this assay, from the lowest: compounds 4, 1, 3 and 2 (each within the scatter of the next, the first and the last beyond it).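

In this assay, diethylamino in place of piperidin-1-yl now gives a 2.0-fold lower number from compound 3 to compound 4 (0.31 log units; beyond the scatter), so this change on the saturated chain carbon does not carry over as one step from the bromo core to the chloro core: the same change on two cores in this assay, a 1.7-fold higher number (0.23 log units; within the scatter) from compound 1 to compound 2 and a 2.0-fold lower number (0.31 log units; beyond the scatter) from compound 3 to compound 4, 3.4-fold (0.53 log units) apart, beyond the scatter of two such steps. Chloro in place of bromo on the aromatic carbon likewise depends on the amine, and with diethylamino it gives a 3.2-fold lower number from compound 2 to compound 4 (0.51 log units; beyond the scatter): the same change on two cores in this assay, a 1.1-fold higher number (0.02 log units; within the scatter) from compound 1 to compound 3 and a 3.2-fold lower number (0.51 log units; beyond the scatter) from compound 2 to compound 4, 3.4-fold (0.53 log units) apart, beyond the scatter of two such steps. The two changes therefore cannot be treated as independent in these four compounds. From the compounds shown here alone, it remains open whether this dependence extends to other amines, such as morpholin-4-yl or pyrrolidin-1-yl, or to fluoro on the aromatic carbon.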